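The source may report more compounds than this note shows. Statements on the series, on what has been measured and on what is new or still open speak of the compounds shown alone.

Measured compounds, a functional assay on BJAB cells (Homo sapiens) for antiproliferative activity, with a stated time of 4 days; a higher number here means that more compound is needed for the effect, a lower number that less compound is needed:
- compound 1 `Cc1nn(-c2nc(-c3ccc(Cl)c(Cl)c3)c(SC(C)C)s2)c(C(=O)O)c1-c1cccc(Cl)c1C` gives 5100 nM
- compound 2 `Cc1nn(-c2nc(-c3ccc(Cl)c(Cl)c3)c(SC(C)C)s2)c(C(=O)O)c1-c1ccccc1Cl` gives 13100 nM
- compound 3 `Cc1nn(-c2nc(-c3ccc(Cl)c(Cl)c3)c(SC(C)C)s2)c(C(=O)O)c1-c1cncc(C#N)c1` gives 20000 nM

Compound 3 holds the highest number of the three. Its nearest neighbour is compound 2, with a 1.5-fold higher number from compound 2 to compound 3 (0.18 log units; within the scatter), a gap within the scatter, so these two values cannot be ordered. Its furthest is compound 1, with a 3.9-fold higher number from compound 1 to compound 3 (0.59 log units; beyond the scatter), beyond the scatter, so compound 3 clearly needs more compound than compound 1 for the effect.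

Compound 4 `COc1cc(Cl)cc(-c2c(C)nn(-c3nc(-c4ccc(Cl)c(Cl)c4)c(SC(C)C)s3)c2C(=O)O)c1` has not yet been measured. The change from compound 3 is 3-chloro-5-methoxyphenyl in place of 5-cyanopyridin-3-yl on an aromatic carbon. Within the data shown here, two measured steps bear on it, both ending at compound 3 and both introducing 5-cyanopyridin-3-yl in place of a chlorine-bearing phenyl group: a 3.9-fold higher number from compound 1 to compound 3 (0.59 log units; beyond the scatter) and a 1.5-fold higher number from compound 2 to compound 3 (0.18 log units; within the scatter). The step to compound 4 runs the other way, restoring a chlorine-bearing phenyl group, now 3-chloro-5-methoxyphenyl. Among the measured compounds shown here, a lower number is therefore expected in this assay, of modest size at most, with the two measured steps setting the likely span; the methoxy group has no measured counterpart here, so the estimate stays wide.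

Compound 4 is expected to give 7000 nM, with a range from 2500 nM to 20000 nM. The expected step is a 2.9-fold lower number from compound 3 to compound 4 (0.46 log units; beyond the scatter).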

Compound 4, half-maximal effective concentration: 760 nM
Estimate against measurement, compound 4: 9.2-fold (0.96 log units) above; the measured number lies below the stated range.
By their numbers in this assay, from the lowest: compound 4; then compound 1; then compounds 2 and 3 (each within the scatter of the next).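

In this assay, the aromatic carbon next to the ring atom bearing the carboxy group proves far more responsive to the choice of aryl group than the first three compounds showed: 3-chloro-5-methoxyphenyl brings a 26-fold lower number from compound 3 to compound 4 (1.42 log units; beyond the scatter) and a 17-fold lower number from compound 2 to compound 4 (1.24 log units; beyond the scatter) and also a 6.7-fold lower number from compound 1 to compound 4 (0.83 log units; beyond the scatter) against the best earlier compound. A chlorine on the phenyl group does not by itself account for this, since compound 1 and compound 2 also carry one and both stay clearly higher than compound 4; compound 4 differs from them in bearing a methoxy group and in having no group at the 2-position of the phenyl ring, and these two differences cannot be separated here. No measured evidence on the cause of this drop in the number is available.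

Among these compounds, whether the methoxy group itself, the chlorine or their combination drives the result remains open, as no compound here carries either group alone on an otherwise unsubstituted phenyl ring. Also unresolved is whether an ethoxy group, a hydroxy group or an amine in place of the methoxy group would keep the number near that of compound 4.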